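This account rests on a few compounds, and the source may have more. Where it says the series, first, only, none or still open, it means among the compounds named here.

Values in a functional assay on SGC-7901 cells (Homo sapiens) for antiproliferative activity, read by MTT assay, with a stated time of 72 h (on this read-out lower numbers stand for stronger inhibition and higher numbers for weaker inhibition), for the series so far
Compound 1 `COc1ccc(-c2ccc3ncn(-c4cc(OC)c(OC)c(OC)c4)c3c2)cc1O` gives 44 nM
Compound 2 `COc1cc(-n2cnc3ccc(-c4ccc([N+](=O)[O-])cc4)cc32)cc(OC)c1OC` gives 79 nM
Compound 3 `COc1cc(-n2cnc3ccc(-c4cccc([N+](=O)[O-])c4)cc32)cc(OC)c1OC` gives 380 nM

Compound 3 holds the highest number of the three, the measured steps to it being a 4.8-fold higher number from compound 2 to compound 3 (0.68 log units; beyond the scatter) and an 8.6-fold higher number from compound 1 to compound 3 (0.94 log units; beyond the scatter) on this read-out. Compound 4 `COc1cc(-n2cnc3ccc(-c4ccc(F)cc4)cc32)cc(OC)c1OC` is unmeasured and carries 4-fluorophenyl in place of 3-nitrophenyl on an aromatic carbon at the shared core. Going by the values given here, no fluorinated compound has been measured, so the guidance is indirect. Among the compounds with values here, the nearest precedent is 4-nitrophenyl in compound 2, with a 4.8-fold higher number from compound 2 to compound 3 (0.68 log units; beyond the scatter) separating it from 3-nitrophenyl, while a 1.8-fold higher number from compound 1 to compound 2 (0.25 log units; within the scatter) shows little change. A modest gain is therefore expected, and the estimated change in this assay is a 3.5-fold lower number from compound 3 to compound 4 (0.54 log units; beyond the scatter) overall. For compound 4 the estimate is 110 nM, with an expected range from 40 nM to 300 nM.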

Compound 4, half-maximal inhibitory concentration: 3500 nM
Beside the measured number, compound 4's estimate is 32-fold (1.50 log units) below it, outside the stated range (above it).
By their numbers in this assay, from the lowest: compounds 1 and 2 (each within the scatter of the next); then compound 3; then compound 4.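

In this assay, 4-fluorophenyl gives the weakest result at this position, with a 9.2-fold higher number from compound 3 to compound 4 (0.96 log units; beyond the scatter), a 44-fold higher number from compound 2 to compound 4 (1.65 log units; beyond the scatter) and an 80-fold higher number from compound 1 to compound 4 (1.90 log units; beyond the scatter). Compounds 1 to 3 gave no sign of a loss this large, and fluoro cannot stand in for nitro on this ring without a large rise in the number. Nothing available explains the loss. On these data alone, it remains open whether an amine or a nitrile in the place of the fluoro would restore the lower numbers. As far as these compounds go, it also remains open whether 3-fluorophenyl would differ from 4-fluorophenyl as 3-nitrophenyl differs from 4-nitrophenyl.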